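The compounds below may be only part of what the source reports. "The series", "measured", "known", "first", "only" and "open" are said of these compounds alone.

Working notes on the purine series, growth read-out.

Three members carry a number or a limit in a functional assay on IGROV-1 cells (Homo sapiens) for cytotoxicity, read by sulforhodamine B assay, with a stated time of 48 h; on this read-out higher numbers stand for weaker inhibition of growth and lower numbers for stronger inhibition of growth. Compound 1 `ClCc1ccc(Cn2cnc3c(Cl)ncnc32)cc1` gives 25100 nM in this assay. Compound 3 `ClCc1ccccc1Cn1cnc2nc(Cl)nc(Cl)c21` gives 5240 nM in this assay. Compound 2 `Nc1nc(Cl)c2ncn(Cc3ccccc3CCl)c2n1` reaches only the limit of this assay, > 100000 nM, so for compound 2 the value is a limit and not a number; this is the situation described in the limit of > 100000 nM in this assay, at which 1 of the 3 values shown sits. Among the two actual numbers, compound 1 stands at the higher one, and the gap down to compound 3 lies beyond the usual scatter, so compound 3 shows the stronger growth inhibition of the two on the numbers available.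

The next member is compound 4 `ClCc1ccc(Cn2cnc3c(Cl)nc(Cl)nc32)cc1`, which differs from compound 1 by chloro in place of hydrogen on an aromatic carbon. Going by the values given here, no step between two measured compounds isolates this change, so the size of the step from compound 1 to compound 4 in this assay must be estimated rather than read. Compound 3 also carries a chloro at this place, though it differs from compound 1 elsewhere as well, and compound 3 gives 5240 nM; on that showing a step toward a lower number, beyond the scatter, is expected. The expected step is a 3.1-fold lower number from compound 1 to compound 4 (0.50 log units; beyond the scatter). Compound 4 is accordingly estimated at 8000 nM in this assay, within a range from 2500 nM to 30000 nM.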

Compound 4, concentration for total growth inhibition: 30200 nM
Compound 4: the middle estimate sits 3.8-fold (0.58 log units) below what was measured, and the stated range ends below it.
By their numbers in this assay, from the lowest: compound 3; then compounds 1 and 4 (each within the scatter of the next). At a limit, above all of these: compound 2.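

In this assay, going by these compounds alone, the first direct reading of chloro in place of hydrogen on the aromatic carbon between two ring nitrogen atoms gives a 1.2-fold higher number from compound 1 to compound 4 (0.08 log units; within the scatter); on the core of compound 1, this change at this position therefore produces no step beyond the scatter. Compound 3, which also carries chloro at this place, gives 5240 nM, whereas compound 4 gives 30200 nM, so the chloro alone does not carry a number like that of compound 3 on this core. Nothing at hand gives a measured property that bears on this flat step.

Going by these compounds, compound 3 has no partner with hydrogen at this place, so whether the same change is equally flat on its core remains open. Also open, on these data alone, is whether a group other than chloro on this aromatic carbon, such as methoxy, a carboxylic acid or a longer chain, would shift the number in this assay beyond the scatter.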